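Shortening the alkoxy chain further in the chromanone series

A few compounds are considered here, and "the series" means these few. Any claim that something is new, unique, unknown or untested is made for them only; others in the source may bear on it.

Among the three compounds measured in a functional assay on RAW264.7 cells (Mus musculus) for inhibition, read by immunoassay, with a stated time of 12 h, tested at 30 uM (on this read-out lower numbers stand for less inhibition and higher numbers for more inhibition at the one concentration tested (going by the name of the read-out)), compound 3 `CCCCOc1ccccc1C1CC(=O)c2ccccc2O1` stands lowest, giving 19.3%, against compound 1 `O=C1CC(c2ccccc2OCc2ccc(F)cc2)Oc2ccccc21` at 45.2% and compound 2 `CC(C)CCOc1ccccc1C1CC(=O)c2ccccc2O1` at 47.6%. Compound 4 `CCOc1ccccc1C1CC(=O)c2ccccc2O1` differs from compound 3 in hydrogen in place of ethyl on a saturated chain carbon, two bonds along the chain from an oxygen on an aromatic ring. The step that bears on it is a number 28.3 percentage points lower from compound 2 to compound 3 (beyond the scatter), where removing a methyl from the chain lowered inhibition; a number 25.9 percentage points lower from compound 1 to compound 3 (beyond the scatter) points the same way for a smaller group on that chain carbon. Trimming the chain again is therefore expected to lower the read-out in this assay, giving an estimated a number 9.3 percentage points lower from compound 3 to compound 4 (within the scatter), though compound 3 already sits near the bottom of the scale. For compound 4 the expected value is 10%, within 0% to 28%.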

Compound 4, a percentage reported as inhibition, at one concentration (the size of the read-out at that concentration, not a potency): 29.6%
Compound 4: middle estimate off by 19.6 percentage points, on the low side; measured number above the stated range.
By their numbers in this assay, from the lowest: compound 3; then compound 4; then compounds 1 and 2 (each within the scatter of the next).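

In this assay, cutting butoxy to ethoxy does not extend the earlier fall but reverses it, with a number 10.3 percentage points higher from compound 3 to compound 4 (beyond the scatter), so across these alkoxy chains the read-out does not follow chain length steadily. Even so, the ethoxy compound does not recover the level of the two larger groups, with a number 18 percentage points lower from compound 2 to compound 4 (beyond the scatter) and a number 15.6 percentage points lower from compound 1 to compound 4 (beyond the scatter). Nothing available explains why compound 3 stands lowest. On these data alone, whether a methoxy group or a longer chain such as hexyloxy would continue this uneven course remains open. So does the effect of an amine at the end of the chain.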